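A few compounds are considered here, and "the series" means these few. Any claim that something is new, unique, unknown or untested is made for them only; others in the source may bear on it.

Measured compounds in an ADME assay on MT4 cells (Homo sapiens) for cytotoxicity, read by spectrophotometry, with a stated time of 5 days; on this read-out lower numbers stand for higher toxicity in this test and higher numbers for lower toxicity in this test:

compound 1, `Cc1ccc2c(c1)/C(=N/NC(=S)NO)C(=O)N2CN(C)C`: 651000 nM
compound 2, `CONC(=S)N/N=C1\C(=O)N(CN2CCN(c3ccc(Cl)cc3)CC2)c2ccc(C)cc21`: 300000 nM
compound 3, `Cc1ccc2c(c1)/C(=N/NC(=S)NO)C(=O)N2CN1CCN(c2ccc(Cl)cc2)CC1`: 335000 nM

Compound 2 differs from compound 3 by methyl in place of hydrogen on an oxygen, and in this assay this gave a 1.1-fold lower number from compound 3 to compound 2 (0.05 log units; within the scatter). Compound 4, `CONC(=S)N/N=C1\C(=O)N(CN(C)C)c2ccc(C)cc21`, carries the same change relative to compound 1, namely (methyl in place of hydrogen on an oxygen); the place of the change reads the same in both pairs. How the core of compound 1 differs from the core of compound 3 is not broken down here. Compound 1 and compound 3 are within the scatter of each other, so no order between them is claimed.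

For compound 4 in this assay the expected step is a 1.1-fold lower number from compound 1 to compound 4 (0.04 log units; within the scatter), resting on compound 3 to compound 2 giving a 1.1-fold lower number from compound 3 to compound 2 (0.05 log units; within the scatter). Compound 4 is therefore estimated at 600000 nM, with the expected range 300000 nM to 1200000 nM.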

Compound 4, half-maximal cytotoxic concentration: 622000 nM
Compound 4: middle estimate off by 1.0-fold (0.02 log units), on the low side, within the range that was stated.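

In this assay, methyl in place of hydrogen on an oxygen gives a 1.0-fold lower number from compound 1 to compound 4 (0.02 log units; within the scatter). Set beside the earlier step, the change reads alike on both cores: the same change on two cores in this assay, a 1.1-fold lower number (0.05 log units; within the scatter) from compound 3 to compound 2 and a 1.0-fold lower number (0.02 log units; within the scatter) from compound 1 to compound 4, 1.1-fold (0.03 log units) apart, within the scatter of two such steps. So hydroxyamino to methoxyamino stays within the scatter on both cores, but with neither step beyond it, no effect of measurable size is shown to carry from one core to the other, and two cores in one assay make no general rule for the series.

Open, as far as these compounds go, is whether a longer chain on that oxygen, such as ethyl or benzyl, would also stay within the scatter. Also open, from the compounds shown here alone, is how an amine in place of the hydroxyamino group would read on these cores.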